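The source may hold more compounds than are shown below. What is called first, only, known or untested is meant among the compounds shown, and "the series" means these compounds.

Measured compounds:
- compound 1 `CN1CCCN(CCn2ccc3ccc(Br)cc32)CC1`: 93%
- compound 2 `CN1CCCN(CCn2ccc3ccc(O)cc32)CC1`: 28%

In an assay on HEK293 cells for binding affinity to 5-hydroxytryptamine receptor 7 (Homo sapiens), read by radioligand binding, tested at 1 uM (a higher number here means more inhibition at the concentration tested (going by the name of the read-out), a lower number less inhibition), compound 1 gives 93%, the highest of the two numbers shown. Among the measured compounds shown here, the only other number comes from compound 2, and the step of a number 65 percentage points lower from compound 1 to compound 2 (beyond the scatter) sets it well apart, the single change being a hydroxy in place of bromo on an aromatic carbon.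

Compound 3 `Brc1ccc2ccn(CCN3CCCNCC3)c2c1` has not yet been measured. It differs from compound 1 by hydrogen in place of methyl on an amine nitrogen in a ring. For the measured compounds named here, no measured step touches that ring nitrogen; the one known step, a number 65 percentage points lower from compound 1 to compound 2 (beyond the scatter), concerns a change on the aromatic ring and so offers no direct guide. The bromo group that compound 1 carries is kept in compound 3. For that reason compound 3 is expected to stay close to compound 1, with a step of a number 13 percentage points lower from compound 1 to compound 3 (beyond the scatter) that is small, and the estimate for compound 3 is 80% within a range from 55% to 95%.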

Compound 3, a percentage reported as inhibition, at one concentration (the size of the read-out at that concentration, not a potency): 77%
Beside the measured number, compound 3's estimate is 3 percentage points above it; low and high end bracket the measured number.
By their numbers in this assay, from the lowest: compound 2; then compound 3; then compound 1.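

Replacing the methyl on the ring amine nitrogen with hydrogen gives a number 16 percentage points lower from compound 1 to compound 3 (beyond the scatter) in this assay and so has a real but modest effect at this position, much smaller than the large step seen at the aromatic carbon, a number 65 percentage points lower from compound 1 to compound 2 (beyond the scatter) in the same assay. The methyl is therefore not essential for a high reading, as compound 3 still gives 77% at the tested concentration. Nothing measured here explains why removing this methyl lowers the number.

The compounds shown leave open how an ethyl group, a longer chain or an acetyl group on this ring nitrogen would compare with methyl and hydrogen. They also leave open whether the same change would produce a step of similar size with hydroxy in place of bromo on the aromatic carbon.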